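A few compounds are considered here, and "the series" means these few. Any claim that something is new, unique, unknown or untested is made for them only; others in the source may bear on it.

Measured so far in a functional assay on HL-60 cells (Homo sapiens) for cytotoxicity, read by MTT assay; a higher number here means a weaker inhibitor, a lower number a stronger inhibitor:
- compound 1 `COc1ccc(S(=O)(=O)NC(C2=CC(=O)c3c(O)ccc(O)c3C2=O)C(C)C)c(OC)c1` gives 400 nM
- compound 2 `CC(C)C(NS(=O)(=O)c1cccc(Br)c1)C1=CC(=O)c2c(O)ccc(O)c2C1=O` gives 790 nM

For the measured compounds named here, compound 2, at 790 nM, lies within the scatter of compound 1, the only other measured compound, so no order can be read between them.

The next compound is compound 3 `CC(C)C(NS(=O)(=O)c1ccccc1Br)C1=CC(=O)c2c(O)ccc(O)c2C1=O`, and the change is 2-bromophenyl in place of 3-bromophenyl on a sulfonyl sulfur. The two have the same atoms, joined differently: 2-bromophenyl in place of 3-bromophenyl on a sulfonyl sulfur.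

Going by the values given here, only one measured step bears on this place: a 2.0-fold higher number from compound 1 to compound 2 (0.30 log units; within the scatter). Among the compounds with values here, no measured compound carries the 2-bromophenyl group, so the data give no direct reading of this change. No step beyond the scatter is expected in this assay. The expected step is a 1.2-fold lower number from compound 2 to compound 3 (0.08 log units; within the scatter). For compound 3 the estimated value is 650 nM, with an expected range from 270 nM to 1600 nM.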

Compound 3, half-maximal inhibitory concentration: 340 nM
For compound 3 the middle estimate is 1.9-fold (0.28 log units) above the measured one, within the range that was stated.
By their numbers in this assay, from the lowest: compounds 3, 1 and 2 (each within the scatter of the next, the first and the last beyond it).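

In this assay, the place on the sulfonyl sulfur now shows a step beyond the scatter from the bromine's placement alone: 2-bromophenyl in place of 3-bromophenyl gives a 2.3-fold lower number from compound 2 to compound 3 (0.37 log units; beyond the scatter), a modest change between groups with the same atoms. Against the 2,4-dimethoxyphenyl group, 2-bromophenyl gives a 1.2-fold lower number from compound 1 to compound 3 (0.07 log units; within the scatter), so no order can be read between those two groups. Nothing on hand accounts for the difference between the two bromophenyl groups.

Going by these compounds, it remains open whether 4-bromophenyl or 2-chlorophenyl on the sulfonyl sulfur would read closer to compound 3 or to compound 2. Also open, on these data alone, is whether a cyclohexyl group, with no aromatic ring at this place, would keep a reading in this range.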